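Aryl for methyl on the pyrazole nitrogen

The source may hold more compounds than are shown below. What is called first, only, known or untested is meant among the compounds shown, and "the series" means these compounds.

Of the compounds shown here, three have been measured in a functional assay on HeLa cells (Homo sapiens) for inhibition, read by MTT assay, with a stated time of 48 h; on this read-out higher numbers stand for weaker inhibition and lower numbers for stronger inhibition. Compound 1 `Cn1cc(NC(=O)c2cccc(NS(=O)(=O)c3ccccc3)c2)cn1` gives 78500 nM; compound 2 `O=C(Nc1cnn(-c2ccccc2)c1)c1cccc(NS(=O)(=O)c2ccc(Cl)cc2)c1` gives 5410 nM; compound 3 `Cn1cc(NC(=O)c2ccc(NS(=O)(=O)c3ccccc3)cc2)cn1` gives 92800 nM. Compound 3 carries the highest number of the three. Its value and that of compound 1 lie within the usual scatter of the method, so nothing separates them, while compound 2 stands well apart with a number far lower than that of compound 3. Compound 2 differs from the others in more than one place, so the two values show only that such a combination of changes can go with a much lower number.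

Compound 4 `COc1cccc(-n2cc(NC(=O)c3ccc(NS(=O)(=O)c4ccccc4)cc3)cn2)c1` has not yet been measured. It arises from compound 3 by one change: 3-methoxyphenyl in place of methyl on an aromatic nitrogen. Going by the values given here, no single-change step of this kind has been measured among the compounds here. Among the compounds with values here, the only guide is compound 2, whose aryl group on the same ring nitrogen goes with the lowest number of the three; on that basis a drop beyond the scatter is expected, though of uncertain size. For compound 4 in this assay a value of about 20000 nM is estimated, in a range from 6000 nM to 60000 nM. That estimate means a step from compound 3 to compound 4 of a 4.6-fold lower number from compound 3 to compound 4 (0.67 log units; beyond the scatter).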

Compound 4, half-maximal inhibitory concentration: 66200 nM
The estimate for compound 4 lay 3.3-fold (0.52 log units) below the measured number; measured number outside the range, above it.
By their numbers in this assay, from the lowest: compound 2; then compounds 4, 1 and 3 (each within the scatter of the next).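

In this assay, going by these compounds alone, the first single-change step at this aromatic nitrogen reads a 1.4-fold lower number from compound 3 to compound 4 (0.15 log units; within the scatter). Replacing methyl with 3-methoxyphenyl puts 8 heavy atoms where there was 1, and adds an aromatic ring and a hydrogen-bond acceptor, yet the values of compound 3 and compound 4 cannot be told apart, so in this core this aryl group does not by itself go with a clearly lower number. Nothing shown here offers an explanation for why so large a replacement leaves the number within the usual scatter.

From the compounds shown here alone, compound 2 differs from compound 4 in more than one place, so it remains open which of its structural differences goes with its much lower number. Going by these compounds, it is also open whether a different group on this nitrogen, such as a longer chain ending in an amine or a carboxylic acid, would give a value that stands apart from those of compound 3 and compound 4.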